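Notes on the step from compound 1 to compound 4

The compounds below may be only part of what the source reports. "The series", "measured", "known", "first", "only" and "open" are said of these compounds alone.

Measured so far in a functional assay on MCF7 cells (Homo sapiens) for antiproliferative activity (a higher number here means a weaker inhibitor, a lower number a stronger inhibitor), for three compounds
- compound 1 `O=C(Nc1ccc(O)c2c(=O)cc(-c3ccccc3Cl)oc12)c1ccc(Cl)c(Cl)c1` gives 15000 nM
- compound 2 `O=C(Nc1c(O)cc(O)c2c(=O)cc(-c3ccccc3Cl)oc12)c1ccc(Cl)cc1` gives 13000 nM
- compound 3 `CC(C)C[C@@H](NC(=O)OC(C)(C)C)C(=O)Nc1ccc(O)c2c(=O)cc(-c3ccccc3Cl)oc12` gives 2500 nM

Compound 1 (15000 nM) and compound 2 (13000 nM) lie within the scatter of each other. Compound 3 (2500 nM) has a lower number than compound 1, beyond the scatter.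

Compound 4 `C[C@H](NC(=O)OC(C)(C)C)C(=O)Nc1ccc(O)c2c(=O)cc(-c3ccccc3Cl)oc12` has not yet been measured. Relative to compound 1, it carries 1-((tert-butoxycarbonyl)amino)ethyl in place of 3,4-dichlorophenyl on a carbonyl carbon. Going by the values given here, no measured pair differs in one place only, so the series offers no direct step as a guide. Among the compounds with values here, compound 3 (2500 nM) is the one measured compound with a tert-butoxycarbonyl amino chain on that carbonyl carbon, and the expectation rests on it.

In this assay the number is expected to fall, by an estimated step (a 3.3-fold lower number from compound 1 to compound 4 (0.52 log units; beyond the scatter)) beyond the scatter. Compound 4 is estimated at 4500 nM (expected range 1500 nM to 13000 nM).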

Compound 4, half-maximal inhibitory concentration: 5500 nM
Beside the measured number, compound 4's estimate is 1.2-fold (0.09 log units) below it, and the stated range covers the measured number.
By their numbers in this assay, from the lowest: compound 3; then compound 4; then compounds 2 and 1 (each within the scatter of the next).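

In this assay, the change at this carbonyl carbon gives a 2.7-fold lower number from compound 1 to compound 4 (0.44 log units; beyond the scatter), so in this pair the 3,4-dichlorophenyl ring is not needed to keep the antiproliferative effect, and an open chain with no ring gives a modest gain. The entering 1-((tert-butoxycarbonyl)amino)ethyl also brings a hydrogen-bond donor and acceptors and a defined stereocentre, and which of these features matters cannot be separated from this single step. Nothing available accounts for the step.

With the same tert-butoxycarbonyl amino chain type, compound 3 gives 2500 nM and compound 4 gives 5500 nM, which leaves open how far the side chain on the stereocentre governs the number. Also open, going by these compounds, is whether the tert-butoxycarbonyl group itself is required, which a free amine at that place would test, and whether the opposite stereocentre behaves alike.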